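Phenylsulfanyl in place of allyloxy on the shared core

This account rests on a few compounds, and the source may have more. Where it says the series, first, only, none or still open, it means among the compounds named here.

In a functional assay on MCF7 cells (Homo sapiens) for antiproliferative activity, read by sulforhodamine B assay, with a stated time of 3 days (a lower number here means a stronger inhibitor, a higher number a weaker inhibitor), compound 1 `c1ccc(Oc2ncnc3ncn(C4COc5ccccc5CO4)c23)cc1` gives 21100 nM. In this assay, among the compounds with values here, compound 2 `C=CCOc1ncnc2ncn(C3COc4ccccc4CO3)c12` gives 20900 nM, which places it within the scatter of compound 1, the only other measured compound.

Compound 3 `c1ccc(Sc2ncnc3ncn(C4COc5ccccc5CO4)c23)cc1` follows from compound 2 with phenylsulfanyl in place of allyloxy on an aromatic carbon. Within the data shown here, one measured step bears on this change: a 1.0-fold lower number from compound 1 to compound 2 (0.00 log units; within the scatter). That exchange of phenyl and allyl on the oxygen produced no separation beyond the scatter. Among the measured compounds shown here, it does not test sulfur in place of oxygen, and no measured compound carries sulfur, so the range is kept wide. The expected step is a 1.1-fold lower number from compound 2 to compound 3 (0.04 log units; within the scatter), and no change beyond the scatter is expected in this assay. For compound 3 the estimate is 19000 nM, with an expected range of 8000 nM to 45000 nM.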

Compound 3, half-maximal inhibitory concentration: 15600 nM
Beside the measured number, compound 3's estimate is 1.2-fold (0.09 log units) above it; the range from low to high includes it.
By their numbers in this assay, from the lowest: compounds 3, 2 and 1 (each within the scatter of the next).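

In this assay, the exchange of the linking oxygen for sulfur with the phenyl ring kept is now tested directly: phenylsulfanyl in place of phenoxy gives a 1.4-fold lower number from compound 1 to compound 3 (0.13 log units; within the scatter). Phenylsulfanyl in place of allyloxy on the same aromatic carbon gives a 1.3-fold lower number from compound 2 to compound 3 (0.13 log units; within the scatter), so across phenoxy, allyloxy and phenylsulfanyl no pair at this position separates beyond the scatter. No measurement on hand speaks to the basis of these steps.

Going by these compounds, whether an amine, a carboxylic acid or a longer chain on this aromatic carbon would give a step beyond the scatter remains open. Also open, on these data alone, is how changes elsewhere on the shared core, which is common to compound 1, compound 2 and compound 3, would read in this assay.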